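Swapping the aryl group on the imine carbon of compound 2

The source may report more compounds than this note shows. Statements on the series, on what has been measured and on what is new or still open speak of the compounds shown alone.

Compound 1, `COc1ccc(C2CC(c3ccc4ccccc4c3)=NN2C2=NC(=O)/C(=C3\C(=O)Nc4ccccc43)S2)cc1`, 970 nM; compound 2, `COc1ccc(C2=NN(C3=NC(=O)/C(=C4\C(=O)Nc5ccccc54)S3)C(c3ccc(Cl)cc3)C2)cc1`, 100000 nM.

In a functional assay on cells (Cancer cell lines, Homo sapiens) for cytotoxicity, read by sulforhodamine B assay, with a stated time of 48 h (on this read-out lower numbers stand for stronger inhibition of growth and higher numbers for weaker inhibition of growth), compound 2 gives the highest of the two numbers, and compound 1 gives the lower number, a gap well beyond the scatter. Compound 3, `O=C1N=C(N2N=C(c3ccc4ccccc4c3)CC2c2ccc(Cl)cc2)S/C1=C1/C(=O)Nc2ccccc21`, is not yet measured. It differs from compound 2 by naphthalen-2-yl in place of 4-methoxyphenyl on a carbon with a double bond to nitrogen. Compound 3 thereby carries the same group on that carbon as compound 1 does. Compound 3 is expected to give a number close to that of compound 1, with the step of a 50-fold lower number from compound 2 to compound 3 (1.70 log units; beyond the scatter) expected to be large in this assay, toward stronger inhibition. The estimate for compound 3 is 2000 nM, within 500 nM to 20000 nM.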

Compound 3, concentration for 50% growth inhibition: 15400 nM
Beside the measured number, compound 3's estimate is 7.7-fold (0.89 log units) below it, and the stated range covers the measured number.
By their numbers in this assay, from the lowest: compound 1; then compound 3; then compound 2.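

With a 4-chlorophenyl group on the ring, naphthalen-2-yl in place of 4-methoxyphenyl on the carbon with a double bond to nitrogen gives a 6.5-fold lower number from compound 2 to compound 3 (0.81 log units; beyond the scatter) in this assay, so this position does affect growth inhibition. That group does not set the level alone, since chloro in place of methoxy on an aromatic carbon, with naphthalen-2-yl kept, gives a 16-fold higher number from compound 1 to compound 3 (1.20 log units; beyond the scatter) in this assay. Nothing measured here accounts for either step.

From the compounds shown here alone, it remains open how a pyridin-3-yl group would behave on the carbon with a double bond to nitrogen, and how an amine or a hydroxy group would compare with chloro and methoxy on the aromatic carbon.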